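The source may hold more compounds than are shown below. What is called first, only, known or untested is meant among the compounds shown, and "the series" means these compounds.

Compound 1, `CCN1CCCC1CNC(=O)c1cc(N(C)S(C)(=O)=O)c(C)cc1OC`: in a functional assay on the whole organism for inhibition, with Mus musculus as the target (on this read-out higher numbers stand for an effect only at larger amounts of compound and lower numbers for an effect already at smaller amounts), compound 1 gives 26.1 mg/kg.
Compound 2, `CCN1CCCC1CNC(=O)c1cc(NS(=O)(=O)N(C)C)ccc1OC`: in this assay compound 2 gives > 50 mg/kg, which is a limit of the assay and not a number.

Among the compounds with values here, compound 2 therefore stands at the limit of > 50 mg/kg in this assay, at which 1 of the 2 values shown sits, so its true place on the scale is open upward, and no measured step links it to compound 1, whose value simply lies inside the resolved range. Compound 3, `CCN1CCCC1CNC(=O)c1cc(NS(=O)(=O)N(C)C)c(C)cc1OC`, differs from compound 2 by methyl in place of hydrogen on an aromatic carbon, ortho to a (dimethylsulfamoyl)amino group and meta to a methoxy group. Compound 1 carries a methyl at that same place and gives a resolved value, but its other group differs, so nothing here sizes the change on its own. Because compound 2 is known only as > 50 mg/kg, the step to compound 3 cannot be anchored to a number. The step of an at least 1.2-fold lower number from compound 2 to compound 3 (0.09 log units; that floor lies within the scatter) is expected to be small, toward smaller amounts if anything. Compound 3 is accordingly estimated at 40 mg/kg in this assay, with a range from 15 mg/kg to 100 mg/kg, and a real chance that only a limit is again reported.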

Compound 3, dose for half-maximal effect: 13.3 mg/kg
The estimate for compound 3 lay 3.0-fold (0.48 log units) above the measured number; measured number below the stated range.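

Within the data shown here, on the aromatic carbon ortho to a (dimethylsulfamoyl)amino group and meta to a methoxy group, methyl in place of hydrogen gives, in this assay, an at least 3.7-fold lower number from compound 2 to compound 3 (0.57 log units; beyond the scatter), the first step at this position that can be read and one that clears the scatter. On these data alone, compound 2 is held at a limit and not a number, so this step is only a floor and its true size stays unknown: the limit of > 50 mg/kg in this assay, at which 1 of the 3 values shown sits. With the methyl present on both sides, (dimethylsulfamoyl)amino in place of methyl(methylsulfonyl)amino gives a 2.0-fold lower number from compound 1 to compound 3 (0.29 log units; within the scatter), so these two groups are not separated on this read-out, and the gain seen with the methyl is not tied to a difference between them.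

Still open, as far as these compounds go, is how large the methyl step really is, and whether it holds to the same extent in a compound carrying methyl(methylsulfonyl)amino. Also open, from the compounds shown here alone, is whether a chlorine atom or an ethyl group on this same aromatic carbon would act as the methyl does.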